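Bromine on the furan ring of compound 2

A few compounds are considered here, and "the series" means these few. Any claim that something is new, unique, unknown or untested is made for them only; others in the source may bear on it.

Measured so far in a functional assay on SW480 cells (Homo sapiens) for inhibition, read by MTT assay, with a stated time of 72 h; a lower number here means a stronger inhibitor of growth, a higher number a weaker inhibitor of growth:
- Compound 1, `N#C/C(=C\c1c(F)c(F)c(F)c(F)c1F)C(=O)c1c[nH]c2ccccc12`, gives 18000 nM.
- Compound 2, `COc1ccc(CNC(=O)/C(C#N)=C/c2ccco2)cc1`, gives 31000 nM.
- Compound 3, `COc1ccc(CNC(=O)/C(C#N)=C/c2ccc(-c3ccccc3)o2)cc1`, gives > 100000 nM; this value is a limit of the assay, not a number.

Among the numbers shown, compound 2 and compound 1 sit within the usual scatter of each other, so neither can be called the stronger. Compound 3 shares the core of compound 2 and differs only by a phenyl in place of hydrogen on an aromatic carbon; that change gave an at least 3.2-fold higher number from compound 2 to compound 3 (0.50 log units; beyond the scatter), where the limit of > 100000 nM in this assay, at which 1 of the 3 values shown sits, sets the value reported.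

Compound 4, `COc1ccc(CNC(=O)/C(C#N)=C/c2cc(Br)co2)cc1`, has not yet been measured. It differs from compound 2 by bromo in place of hydrogen on an aromatic carbon. Among the measured compounds shown here, only the step from compound 2 to compound 3 bears on this, and it concerns a larger group at a different aromatic carbon of the same ring, so it gives no firm guide. A bromo group is small, and a step of about a 1.1-fold higher number from compound 2 to compound 4 (0.05 log units; within the scatter) is expected, with no change beyond the scatter as the most likely outcome. Compound 4 is therefore estimated at 35000 nM in this assay, within a range of 12000 nM to 100000 nM.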

Compound 4, concentration for 50% growth inhibition: > 100000 nM
Compound 4 was reported as a limit; the forecaster's own chance of this, stated with the estimate: 20%; middle value at least 2.8-fold (0.45 log units) away from the limit.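

In this assay, a single bromine atom in place of hydrogen, turning furan-2-yl into 4-bromofuran-2-yl, gives an at least 3.2-fold higher number from compound 2 to compound 4 (0.50 log units; beyond the scatter). Among the compounds shown here, until now, the only change to this furan ring that weakened growth inhibition was a phenyl group, which brings a whole ring, at a different aromatic carbon; this step shows that bromo, with no ring, also weakens it, here at the carbon two ring bonds from the ring oxygen. The result for compound 4 is a limit of the assay and not a number, so the true size of its step remains unknown: the limit of > 100000 nM in this assay, at which 2 of the 4 values shown sit.

The compounds shown leave open whether a methyl group, a chlorine atom or an amine on this same carbon would keep the number close to that of compound 2. They also leave open whether bromo on the carbon that carries the phenyl in compound 3 would give the same outcome.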